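Pyrazole for Pyrimidine on the Shared Core

This account rests on a few compounds, and the source may have more. Where it says the series, first, only, none or still open, it means among the compounds named here.

In a functional assay on BJAB cells (Homo sapiens) for antiproliferative activity, with a stated time of 4 days (a higher number here means that more compound is needed for the effect, a lower number that less compound is needed), compound 1 `Cc1nn(-c2nc(-c3ccc(Cl)c(Cl)c3)c(SC(C)C)s2)c(C(=O)O)c1-c1cncnc1` gives 22000 nM, the lowest of the two numbers measured. For the measured compounds named here, compound 2 `COC(=O)c1c(Cc2ccccc2[N+](=O)[O-])c(C)nn1-c1nc(-c2ccc(Cl)c(Cl)c2)c(SC(C)C)s1` gives 93000 nM in this assay, a gap beyond the scatter; no single-point step between measured compounds is available. Compound 3 `Cc1nn(-c2nc(-c3ccc(Cl)c(Cl)c3)c(SC(C)C)s2)c(C(=O)O)c1-c1cnn(C)c1` differs from compound 1 by 1-methyl-1H-pyrazol-4-yl in place of pyrimidin-5-yl on an aromatic carbon, one aromatic ring with 2 hetero atoms replacing another, both with 0 hydrogen-bond donors and 2 hydrogen-bond acceptors. With nothing measured on such a swap, the step from compound 1 to compound 3 is estimated as no change at the digits printed from compound 1 to compound 3 (within the scatter), expected to stay within the scatter in no fixed direction. Compound 3 is expected to give 22000 nM, with a range from 7000 nM to 65000 nM.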

Compound 3, half-maximal effective concentration: 6800 nM
Beside the measured number, compound 3's estimate is 3.2-fold (0.51 log units) above it; measured number below the stated range.
By their numbers in this assay, from the lowest: compound 3; then compound 1; then compound 2.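

For the compounds shown here, on the aromatic carbon next to the ring atom that bears a carboxy group, 1-methyl-1H-pyrazol-4-yl in place of pyrimidin-5-yl gives a 3.2-fold lower number from compound 1 to compound 3 (0.51 log units; beyond the scatter) in this assay, the first single-place step. This position therefore responds to the identity of the aromatic ring, even with the heavy-atom, donor and acceptor counts unchanged. No measured property bears on this modest step.

Still open, going by these compounds, is whether a phenyl ring or a pyrazole without the methyl group at this position follows the same direction. Also open, on these data alone, is whether the step holds with an amide in place of the carboxy group.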